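Pyrrolidine to piperidine swap on the propoxy chain

The compounds below may be only part of what the source reports. "The series", "measured", "known", "first", "only" and "open" are said of these compounds alone.

Compound 1 `COc1cc2c(Oc3ccc(NC(=O)c4nnn(-c5ccccc5C)c4C)cc3F)ccnc2cc1OCCCN1CCCC1` carries a pyrrolidin-1-yl group at the end of the propoxy chain; in a functional assay on U-87MG ATCC cells (Homo sapiens) for cytotoxicity, read by MTT assay, with a stated time of 72 h (a lower number here means a stronger inhibitor, a higher number a weaker inhibitor), compound 1 gives 1600 nM. Compound 3 `COc1cc2c(Oc3ccc(NC(=O)c4nnn(-c5ccccc5C)c4C)cc3F)ccnc2cc1OCCCN1CCCCC1` is the matching piperidin-1-yl analogue, differing from compound 1 by piperidin-1-yl in place of pyrrolidin-1-yl on a saturated chain carbon, three bonds along the chain from an oxygen on an aromatic ring; in this assay compound 3 gives 2370 nM. The step is a 1.5-fold higher number from compound 1 to compound 3 (0.17 log units; within the scatter), so the two numbers are not separated beyond the usual scatter.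

Compound 2 `COc1cc2c(Oc3ccc(NC(=O)c4nnn(-c5ccc(F)cc5)c4C(F)(F)F)cc3F)ccnc2cc1OCCCN1CCCC1` has a different amide-side core, and the difference between the core of compound 1 and the core of compound 2 is not broken down here. In this assay compound 2 gives 850 nM, the lowest of the three numbers measured; it lies within the scatter of compound 1 but beyond it relative to compound 3.

Compound 4 `COc1cc2c(Oc3ccc(NC(=O)c4nnn(-c5ccc(F)cc5)c4C(F)(F)F)cc3F)ccnc2cc1OCCCN1CCCCC1` has not been measured. It relates to compound 2 as compound 3 relates to compound 1, by piperidin-1-yl in place of pyrrolidin-1-yl on a saturated chain carbon, three bonds along the chain from an oxygen on an aromatic ring, the same change at the same place on the chain. Among the measured compounds shown here, with only one measured instance of this change, the expectation for compound 4 rests on that single step, a 1.5-fold higher number from compound 1 to compound 3 (0.17 log units; within the scatter), applied to the number of compound 2. The expected step is therefore a 1.5-fold higher number from compound 2 to compound 4 (0.18 log units; within the scatter), small enough that it may not be resolved from the parent number. Compound 4 is accordingly estimated at 1300 nM in this assay. Compound 4 is expected to fall between 650 nM and 2600 nM.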

Compound 4, half-maximal inhibitory concentration: 1100 nM
Estimate against measurement, compound 4: 1.2-fold (0.07 log units) above; low and high end bracket the measured number.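

In this assay, piperidin-1-yl in place of pyrrolidin-1-yl on a saturated chain carbon, three bonds along the chain from an oxygen on an aromatic ring, gives a 1.3-fold higher number from compound 2 to compound 4 (0.11 log units; within the scatter). Set beside the earlier step, the change carries from one core to the other with no difference that can be separated from the usual scatter: the same change on two cores in this assay, a 1.5-fold higher number (0.17 log units; within the scatter) from compound 1 to compound 3 and a 1.3-fold higher number (0.11 log units; within the scatter) from compound 2 to compound 4, 1.1-fold (0.06 log units) apart, within the scatter of two such steps. Among the compounds shown here, this shows only that on these two cores the swap stays within the scatter each time; it does not give a resolved size for the change, and two matched pairs do not show that a third core would behave the same way.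

Still open, on these data alone, is whether a different amine at the end of the chain, such as morpholin-4-yl or dimethylamino, or a longer chain than the propyl linker, would give a step beyond the scatter in this assay. For the compounds shown here, also open is which of the several differences between the core of compound 1 and the core of compound 2 bears on the number, as each matched pair keeps its own core fixed and no pair here changes one part of the core alone.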